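The source may hold more compounds than are shown below. What is called first, only, known or untested is meant among the compounds shown, and "the series" means these compounds.

Measured compounds:
compound 1 `O=C(O)COc1ccc(-c2coc3cc(OCC(=O)O)ccc3c2=O)cc1` — >> 9000 nM
compound 2 `O=C(O)CCCCCCCCCCCCCCCOc1ccc2c(=O)c(-c3ccc(O)cc3)coc2c1` — > 9000 nM
compound 3 `O=C(O)CCCCOc1ccc2c(=O)c(-c3ccc(O)cc3)coc2c1` — 100 nM

Three compounds that share a core have been examined in an assay (Cricetulus griseus) for inhibition of aldehyde dehydrogenase, mitochondrial (Homo sapiens); a higher number here means a weaker inhibitor, a lower number a stronger inhibitor. Compound 1 `O=C(O)COc1ccc(-c2coc3cc(OCC(=O)O)ccc3c2=O)cc1` reaches only a limit of the assay, >> 9000 nM. Compound 2 `O=C(O)CCCCCCCCCCCCCCCOc1ccc2c(=O)c(-c3ccc(O)cc3)coc2c1` likewise sits at a limit, > 9000 nM. Among the compounds with values here, compound 3 `O=C(O)CCCCOc1ccc2c(=O)c(-c3ccc(O)cc3)coc2c1` is the one compound that gives a number in this assay, 100 nM, and so stands alone as the only fixed point among the three values shown.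

Compound 4 `O=c1c(-c2ccc(O)cc2)coc2cc(OCCCCCCCCCO)ccc12` has not yet been measured in this assay. It differs from compound 3 in one place: 5-hydroxypentyl in place of carboxy on a saturated chain carbon, four bonds along the chain from an oxygen on an aromatic ring. Within the data shown here, no step between measured compounds is available for this change, so the expectation rests on the three values shown. Compound 2 carries a far longer acid chain than compound 3 and sits at a limit, which speaks for caution when the chain is lengthened and the acid removed. Compound 4 is therefore expected to be a weaker inhibitor than compound 3, with a step of a 15-fold higher number from compound 3 to compound 4 (1.18 log units; beyond the scatter) estimated beyond the scatter. The estimate for compound 4 in this assay is 1500 nM, within a range from 250 nM to 9000 nM.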

Compound 4, half-maximal inhibitory concentration: 700 nM
For compound 4 the middle estimate is 2.1-fold (0.33 log units) above the measured one, and the stated range covers the measured number.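

In this assay, replacing carboxy with 5-hydroxypentyl at this place on the chain gives a 7.0-fold higher number from compound 3 to compound 4 (0.85 log units; beyond the scatter), which shows that a chain without a terminal carboxy can still give a measured number, although a higher one than compound 3 gives. Compound 2 stands at > 9000 nM, which is a limit of the assay and not a number. With hydroxy in place of 6-carboxyhexyl, the change reads as an at least 12-fold lower number from compound 2 to compound 4 (1.10 log units; beyond the scatter), so among these compounds a long chain does not by itself put a compound at the limit, as the earlier compounds alone might have suggested.

The compounds shown offer no measured property that accounts for either step. They also leave open how the number would move with an amine or an amide at the end of the chain in place of hydroxy, and whether a carboxylic acid on a chain of intermediate length would stay close to compound 3 or move towards the limit seen for compound 2.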